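Swapping amino for hydroxy in compound 3

The compounds below may be only part of what the source reports. "The series", "measured", "known", "first", "only" and "open" are said of these compounds alone.

compound 1 `COc1ccc(-n2ccnc2-c2cc(OC)c(OC)c(OC)c2)cc1[N+](=O)[O-]`: 10000 nM
compound 2 `COc1ccc(-n2ccnc2-c2cc(OC)c(OC)c(OC)c2)cc1`: 1400 nM
compound 3 `COc1ccc(-n2ccnc2-c2cc(OC)c(OC)c(OC)c2)cc1N`: 500 nM

These values come from a functional assay on T47D cells (Homo sapiens) for antiproliferative activity, read by MTT assay, with a stated time of 72 h; a lower number here means a stronger inhibitor, a higher number a weaker inhibitor. Here compound 3 is the strongest of the three, and its gaps to both others lie beyond the scatter. The next change replaces its amino group with a hydroxy group, giving compound 4 `COc1ccc(-n2ccnc2-c2cc(OC)c(OC)c(OC)c2)cc1O`: hydroxy in place of amino on an aromatic carbon. The new group sits on an aromatic carbon, ortho to a methoxy group and meta to a large group.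

Three measured steps change this same place. Hydrogen in place of nitro gives a 7.1-fold lower number from compound 1 to compound 2 (0.85 log units; beyond the scatter). Amino in place of nitro gives a 20-fold lower number from compound 1 to compound 3 (1.30 log units; beyond the scatter). Amino in place of hydrogen gives a 2.8-fold lower number from compound 2 to compound 3 (0.45 log units; beyond the scatter). The group at this place clearly moves the number, but none of these steps involves a hydroxy group, so the data do not settle the direction. The swap of amino for hydroxy is a close one, so a step smaller than a 2.8-fold lower number from compound 2 to compound 3 (0.45 log units; beyond the scatter) seems likely, with none expected beyond the scatter. The estimated change is a 1.3-fold lower number from compound 3 to compound 4 (0.10 log units; within the scatter). For compound 4 the expected value is 400 nM, with an estimated range of 100 nM to 1500 nM.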

Compound 4, half-maximal inhibitory concentration: 53100 nM
Compound 4: the middle estimate sits 130-fold (2.12 log units) below what was measured; measured number outside the range, above it.
By their numbers in this assay, from the lowest: compound 3; then compound 2; then compound 1; then compound 4.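

In this assay, going by these compounds alone, this position proves far more sensitive than the earlier compounds suggested: amino and hydroxy match in their counts of heavy atoms, hydrogen-bond donors and hydrogen-bond acceptors, yet swapping one for the other gives a very large loss of strength (a 110-fold higher number from compound 3 to compound 4 (2.03 log units; beyond the scatter)). Hydroxy also does worse here than hydrogen (a 38-fold higher number from compound 2 to compound 4 (1.58 log units; beyond the scatter)) and even worse than nitro, previously the weakest group at this place (a 5.3-fold higher number from compound 1 to compound 4 (0.73 log units; beyond the scatter)), so the group with the highest number is now a close match for the one with the lowest. Matching counts are therefore a poor guide at this position, and nothing measured here accounts for the gap between these two groups.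

The compounds shown leave open whether this loss is particular to the hydroxy group or would also appear with an ethoxy group or a fluorine atom at this place. They also leave open whether a methylamino group or an acetamide would keep the strength of compound 3 or lose it.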